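The source may hold more compounds than are shown below. What is called first, only, known or untested is meant among the compounds shown, and "the series" means these compounds.

Three compounds of one series were examined in a functional assay on K562 cells (Homo sapiens) for cytotoxicity, read by MTT assay, with a stated time of 72 h; on this read-out lower numbers stand for stronger inhibition and higher numbers for weaker inhibition. For the measured compounds named here, compound 1 `COCOc1cc(/C=C/C(=O)OCC(=O)Nc2ccc(OC)cc2)ccc1OCc1ccccc1` is the first of them. In this assay compound 1 gives > 200000 nM, which is a limit of the assay and not a number. Compound 2 `COCOc1cc(/C=C/C(=O)OCC(=O)Nc2ccc(Cl)cc2)ccc1OCc1ccccc1` differs from compound 1 only by chloro in place of methoxy on an aromatic carbon. In this assay compound 2 gives > 200000 nM, again a limit rather than a number. The step that the two limits leave unreadable from compound 1 to compound 2 therefore cannot be sized. Compound 3 `COc1ccc(NC(=O)COC(=O)/C=C/c2cc(OC)c(OCc3ccc(Cl)c(Cl)c3)c(OC)c2)cc1` rests on a different core; how the core of compound 3 differs from the core of compound 1 is not broken down here. In this assay compound 3 gives > 200000 nM, which is also a limit. All three results sit at the limit of > 200000 nM in this assay, at which 3 of the 3 values shown sit.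

Compound 4 `COc1cc(/C=C/C(=O)OCC(=O)Nc2ccc(Cl)cc2)cc(OC)c1OCc1ccc(Cl)c(Cl)c1` has not yet been measured in this assay. It differs from compound 3 by chloro in place of methoxy on an aromatic carbon, the same change that separates compound 1 from compound 2, and it falls in the same place. The earlier step gave no readable size, so there is no measured change to carry over. The step from compound 3 to compound 4 is expected to be a step that the limit leaves unreadable from compound 3 to compound 4, because the limit of > 200000 nM in this assay, at which 3 of the 3 values shown sit, holds compound 1, compound 2 and compound 3 alike and leaves no sign that this change moves the read-out. Compound 4 is accordingly expected to give about 250000 nM in this assay, most likely between 100000 nM and 1000000 nM, and most probably only as a limit once more.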

Compound 4, half-maximal inhibitory concentration: > 200000 nM
Compound 4 was reported as a limit; the forecaster's own chance of this, stated with the estimate: 85%; the middle value lies beyond the limit too.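

In this assay compound 4 gives > 200000 nM, which is again a limit and not a number. For the compounds shown here, the step from compound 3 to compound 4 therefore cannot be read, any more than the one from compound 1 to compound 2: the limit of > 200000 nM in this assay, at which 4 of the 4 values shown sit. The compounds shown leave open whether chloro in place of methoxy moves the read-out at all, and whether any compound of this series gives a measurable value in this assay.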